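Swapping the Naphthyl Group for a Difluorophenyl Ring

The compounds below may be only part of what the source reports. "The series", "measured", "known", "first", "only" and "open" are said of these compounds alone.

Within the data shown here, compound 2 `Nc1scc(CN2CCN(c3cccc4ccccc34)CC2)c1C(=O)c1ccc(Cl)cc1` gives 8.7% in a functional assay on CHO cells with adenosine receptor A1 (Homo sapiens) as the target, read by cAMP accumulation and immunoassay, with a stated time of 6 min, tested at 0.01 uM (a lower number here means a stronger effect, a higher number a weaker effect of the compound at the concentration tested), the higher of the two numbers measured so far. Compound 1 `Nc1scc(CN2CCN(c3cccc(C(F)(F)F)c3)CC2)c1C(=O)c1ccc(Cl)cc1` gives -8.2% in this assay. Among the measured compounds shown here, the one measured step, a number 16.9 percentage points higher from compound 1 to compound 2 (beyond the scatter), bears on the change to compound 3 `Nc1scc(CN2CCN(c3c(F)cccc3F)CC2)c1C(=O)c1ccc(Cl)cc1`, in which (2,6-difluorophenyl in place of naphthalen-1-yl on an amine nitrogen in a ring). That step placed naphthalen-1-yl in place of 3-(trifluoromethyl)phenyl on an amine nitrogen in a ring; compound 3 returns to a single phenyl ring there, so a step of about a number 11.7 percentage points lower from compound 2 to compound 3 (beyond the scatter) is expected, reversing much of it. Compound 3 is therefore estimated at -3%, with a range from -18% to 12%.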

Compound 3, a percentage reported as activity, at one concentration (the size of the read-out at that concentration, not a potency): -12%
Compound 3: the middle estimate sits 9 percentage points above what was measured; the measured number falls inside the stated range.
By their numbers in this assay, from the lowest: compounds 3 and 1 (each within the scatter of the next); then compound 2.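

At this amine nitrogen, going from naphthalen-1-yl to 2,6-difluorophenyl gives a number 20.7 percentage points lower from compound 2 to compound 3 (beyond the scatter) in this assay, so a single fluorinated ring restores the low reading. Exchanging 3-(trifluoromethyl)phenyl for 2,6-difluorophenyl gives a number 3.8 percentage points lower from compound 1 to compound 3 (within the scatter) and therefore separates these two single-ring groups by no meaningful amount, leaving naphthalen-1-yl as the one group that stands apart among these compounds. No available evidence explains this difference. Still open, from the compounds shown here alone, is whether an unsubstituted phenyl ring, a methoxyphenyl ring or a pyridine ring would read like these single rings or like naphthalen-1-yl.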